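The compounds below may be only part of what the source reports. "The series", "measured", "known", "first", "only" and "open" are said of these compounds alone.

Going by the values given here, compound 1 `COc1ccc(C(=O)/C=C/c2ccc(N(C)C)cc2)c2c1C=CC(C)(C)O2` holds the only number given: in a functional assay on K562 cells (Homo sapiens) for antiproliferative activity, read by MTT assay, with a stated time of 24 h (on this read-out lower numbers stand for stronger inhibition and higher numbers for weaker inhibition), compound 1 gives 3500 nM. Compound 2 `COc1ccc(C(=O)/C=C/c2ccc(C(F)(F)F)cc2)c2c1C=CC(C)(C)O2` sits at a limit of this assay rather than at a number, since in this assay compound 2 gives > 10000 nM; it rests on (the limit of > 10000 nM in this assay, at which 1 of the 2 values shown sits). Among the compounds with values here, the sole measured step, an at least 2.8-fold higher number from compound 1 to compound 2 (0.45 log units; beyond the scatter), concerns a different replacement of the dimethylamino group and so bears only loosely on compound 3 `COc1ccc(C(=O)/C=C/c2cccc(O)c2)c2c1C=CC(C)(C)O2`, which differs from compound 1 by 3-hydroxyphenyl in place of 4-(dimethylamino)phenyl on a double-bonded chain carbon bound to a double-bonded chain carbon. Losing the dimethylamino group once weakened activity, so a weaker result is expected for compound 3, namely a 2.0-fold higher number from compound 1 to compound 3 (0.30 log units; within the scatter). Compound 3 is therefore estimated at 7000 nM, between 2500 nM and 20000 nM.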

Compound 3, half-maximal inhibitory concentration: > 10000 nM
Compound 3: a limit, no number (the forecaster's own chance of this, stated with the estimate: 35%); middle value at least 1.4-fold (0.15 log units) from the limit.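

Placing 3-hydroxyphenyl in place of 4-(dimethylamino)phenyl on a double-bonded chain carbon bound to a double-bonded chain carbon gives an at least 2.8-fold higher number from compound 1 to compound 3 (0.45 log units; beyond the scatter), so a second, different replacement at this place also loses activity in this assay. Compound 3 gives > 10000 nM, which is a limit of the assay and not a number. The true size of this loss therefore stays unknown: the limit of > 10000 nM in this assay, at which 2 of the 3 values shown sit.

The compounds shown do not separate the change of group from the change of ring position in compound 3. As far as these compounds go, it remains open how a 4-hydroxyphenyl or a 4-(diethylamino)phenyl group would fare at this place.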